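Swapping Chloro for Nitro on a Styryl Benzyl Sulfone

A few compounds are considered here, and "the series" means these few. Any claim that something is new, unique, unknown or untested is made for them only; others in the source may bear on it.

Three measured compounds share a styryl sulfone joined to a benzyl group, tested in a functional assay on DLD-1 cells (Homo sapiens) for antiproliferative activity, read by trypan blue exclusion; a lower number here means a stronger inhibitor, a higher number a weaker inhibitor. Compound 1 `COc1ccc(/C=C/S(=O)(=O)Cc2ccc(OC)cc2)cc1` reaches only a limit of the assay, reported as > 20000 nM. Compound 2 `COc1cc(OC)c(/C=C/S(=O)(=O)Cc2cc(OC)c(OC)c(OC)c2)c(OC)c1` likewise returns a limit in this assay, > 20000 nM. Among the compounds with values here, compound 3 `COc1cc(OC)c(/C=C/S(=O)(=O)Cc2ccc(Cl)cc2)c(OC)c1` is the one compound with a real number, giving 15000 nM in this assay, so it stands as the sole measured point, with the two other values sitting at the limit of > 20000 nM in this assay, at which 2 of the 3 values shown sit.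

Compound 4 `COc1cc(OC)c(/C=C/S(=O)(=O)Cc2ccc([N+](=O)[O-])cc2)c(OC)c1` differs from compound 3 in a single place: nitro in place of chloro on an aromatic carbon. Within the data shown here, no pair of measured compounds differing in one place exists, so no measured step guides the expectation, and the gap is filled by an estimate alone. A change of modest size toward stronger inhibition is expected, with wide uncertainty. Compound 4 is expected to give about 4000 nM, in a range from 400 nM to 20000 nM. The estimated step, a 3.8-fold lower number from compound 3 to compound 4 (0.57 log units; beyond the scatter), is therefore expected to be larger than ordinary scatter but remains a guess.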

Compound 4, half-maximal inhibitory concentration: 15000 nM
The estimate for compound 4 lay 3.8-fold (0.57 log units) below the measured number; measured number inside the range.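

In this assay, going from 4-chlorophenyl to 4-nitrophenyl gives no change at the digits printed from compound 3 to compound 4 (within the scatter). Within the data shown here, this is the first measured step in the set, and it shows that on this aromatic carbon, para to a large group, a single chlorine and a nitro group of three heavy atoms with two hydrogen-bond acceptors read alike. Compound 3 and compound 4 are also the only two compounds here with real numbers rather than a limit: the limit of > 20000 nM in this assay, at which 2 of the 4 values shown sit.

Going by these compounds, whether the same holds for other groups at this position, such as an amine, a carboxylic acid or a longer chain, stays open. Also open, on these data alone, is whether chloro and nitro would still read alike if the rest of the core of compound 3 were altered.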